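Extending the sulfur-bound chain from isopropyl to tert-butyl

A few compounds are considered here, and "the series" means these few. Any claim that something is new, unique, unknown or untested is made for them only; others in the source may bear on it.

Of the compounds shown here, two sharing one core have been measured in a functional assay on isolated protein for inhibition of Glucose-dependent insulinotropic receptor (Rattus norvegicus), read by HTRF and cAMP accumulation; a lower number here means a smaller maximal response, a higher number a larger maximal response. Compound 1 `Cc1nc(S(C)(=O)=O)ccc1Oc1ncnc(OC2CCN(C(=O)O[C@H](C)C(F)(F)F)CC2)c1F` reaches 85%, and compound 2 `Cc1nc(S(C)(=O)=O)ccc1Oc1ncnc(OC2CCN(C(=O)SC(C)C)CC2)c1F` reaches 81%. Among the measured compounds shown here, of these two numbers the one for compound 2 is the lower, but its nearest neighbour, compound 1, differs from it only by a number 4 percentage points lower from compound 1 to compound 2 (within the scatter), so the two compounds cannot be told apart on this read-out.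

Compound 3 `Cc1nc(S(C)(=O)=O)ccc1Oc1ncnc(OC2CCN(C(=O)SC(C)(C)C)CC2)c1F` has not yet been measured. It differs from compound 2 in one place: methyl in place of hydrogen on a saturated chain carbon bound to two saturated chain carbons and a sulfur.

For the measured compounds named here, only one step among the measured compounds touches this part of the molecule. It exchanged the whole group attached to the carbonyl carbon and gave a number 4 percentage points lower from compound 1 to compound 2 (within the scatter), a change inside the scatter. The present step is smaller in kind, adding a single methyl on the chain bound to the sulfur. With a larger exchange at this place producing no shift beyond the scatter, no shift beyond the scatter is expected here either. The step from compound 2 to compound 3 in this assay is therefore estimated at a number 1 percentage points lower from compound 2 to compound 3 (within the scatter). Compound 3 is expected to reach about 80%, likely between 65% and 95%.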

Compound 3, largest response reached (reported as efficacy), in percent of the reference or control that the assay uses: 76%
For compound 3 the middle estimate is 4 percentage points above the measured one; low and high end bracket the measured number.
By their numbers in this assay, from the lowest: compounds 3, 2 and 1 (each within the scatter of the next).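

Within this assay, the single methyl that turns isopropyl into tert-butyl gives a number 5 percentage points lower from compound 2 to compound 3 (within the scatter) and so does not separate the two sulfur-bound chains, which means a fully branched carbon on the sulfur is compatible with a maximal response in the same range. The wider comparison, (tert-butyl)sulfanyl in place of 1-(trifluoromethyl)ethoxy on the carbonyl carbon, gives a number 9 percentage points lower from compound 1 to compound 3 (within the scatter) and is also not resolved, so the three groups on this carbonyl carbon cannot be told apart on this read-out, although the two individual steps from compound 2 and to compound 2 both point the same way numerically. Nothing is available that could explain this outcome.

As far as these compounds go, what remains open is whether the sulfur itself matters, which tert-butoxy on the same carbonyl carbon would test directly, and whether a longer chain such as n-butyl or a ring such as cyclohexyl on the sulfur would also leave the response unresolved. An amine on the carbonyl carbon, such as piperidine, is a further open case, since all three groups shown attach through oxygen or sulfur.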